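Adding a Methyl to the Methylamino Chain

A few compounds are considered here, and "the series" means these few. Any claim that something is new, unique, unknown or untested is made for them only; others in the source may bear on it.

In a functional assay on MCF7 cells (Homo sapiens) for antiproliferative activity, read by MTT assay, with a stated time of 48 h (a higher number here means a weaker inhibitor, a lower number a stronger inhibitor), the compounds read as follows:
Compound 1 `COc1ccc(C(=O)c2ccc3c(c2)C=CC(C)(C)O3)c(NC(=O)CO)c1` gives 200 nM
Compound 2 `COc1ccc(C(=O)c2ccc3c(c2)C=CC(C)(C)O3)c(NC(=O)CN)c1` gives 680 nM
Compound 3 `CNCC(=O)Nc1cc(OC)ccc1C(=O)c1ccc2c(c1)C=CC(C)(C)O2` gives 1210 nM

Compound 3 (1210 nM) stands within the scatter of compound 2, as a 1.8-fold higher number from compound 2 to compound 3 (0.25 log units; within the scatter) shows, while a 6.1-fold higher number from compound 1 to compound 3 (0.78 log units; beyond the scatter) separates it from compound 1. Compound 4 `CCNCC(=O)Nc1cc(OC)ccc1C(=O)c1ccc2c(c1)C=CC(C)(C)O2` is compound 3 with one change: methyl in place of hydrogen on a saturated chain carbon bound to an amine nitrogen in the form of methyl in place of hydrogen on a saturated chain carbon bound to an amine nitrogen. The nearest measured precedent is a 1.8-fold higher number from compound 2 to compound 3 (0.25 log units; within the scatter) for a methyl on the amine nitrogen itself. The larger 3.4-fold higher number from compound 1 to compound 2 (0.53 log units; beyond the scatter) concerns a different exchange. The expected step is therefore a 1.2-fold higher number from compound 3 to compound 4 (0.09 log units; within the scatter) in this assay with no change beyond the scatter anticipated. Compound 4 is estimated at 1500 nM with 700 nM as the lower end and 3200 nM as the upper end.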

Compound 4, half-maximal inhibitory concentration: 6310 nM
For compound 4 the middle estimate is 4.2-fold (0.62 log units) below the measured one, and the stated range ends below it.
By their numbers in this assay, from the lowest: compound 1; then compounds 2 and 3 (each within the scatter of the next); then compound 4.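

Lengthening methylamino to ethylamino on this chain is the first change at the amine to move the number in this assay beyond the scatter (a 5.2-fold higher number from compound 3 to compound 4 (0.72 log units; beyond the scatter)), whereas the methyl on the amine nitrogen itself stayed within it (a 1.8-fold higher number from compound 2 to compound 3 (0.25 log units; within the scatter)). The ethylamino chain also stands well apart from the plain amino chain (a 9.3-fold higher number from compound 2 to compound 4 (0.97 log units; beyond the scatter)) and further still from the hydroxy chain (a 32-fold higher number from compound 1 to compound 4 (1.50 log units; beyond the scatter)), so a single added carbon at this position can matter. Nothing measured here explains this rise.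

From the compounds shown here alone, whether a propylamino chain or a dimethylamino group would raise the number further remains open. So does whether a carboxylic acid at this position would bring it back towards the hydroxy chain.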